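The source may report more compounds than this note shows. Statements on the series, on what has been measured and on what is new or still open speak of the compounds shown alone.

Measured compounds in a functional assay on WI-38 cells (Homo sapiens) for inhibition; on this read-out lower numbers stand for stronger inhibition and higher numbers for weaker inhibition:
compound 1 `CCC(C)C(NC(=O)n1nnc2ccccc21)C(=O)NC1CCCCC1`: > 100000 nM
compound 2 `CCC(C)C(NC(=O)n1nnc2ccccc21)C(=O)NCc1ccccc1`: > 100000 nM
compound 3 `CC(C)C(NC(=O)n1nnc2ccccc21)C(=O)NC1CCCC1`: >= 100000 nM

Working notes on the series. In this assay compound 1 gives > 100000 nM, which is a limit of the assay and not a number. Compound 2 likewise gives > 100000 nM, again a limit. The step that the two limits leave unreadable from compound 1 to compound 2 is therefore not readable in size or direction. Compound 3 gives >= 100000 nM, also a limit. Among the compounds with values here, compound 3 thus stands at the limit of >= 100000 nM in this assay, at which 1 of the 3 values shown sits, while the other two compounds sit at the limit of > 100000 nM in this assay, at which 2 of the 3 values shown sit; nothing in the measured values separates any of the three from the others, and no compound can be called more or less potent than another.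

Compound 4 `CCC(C)C(NC(=O)n1nnc2ccccc21)C(=O)NC1CCCC1` differs from compound 3 by methyl in place of hydrogen on a saturated chain carbon, three bonds along the chain from an amide-type nitrogen and a carbonyl carbon. Within the data shown here, no measured step isolates this change, and the only measured step, which concerns a different position, is itself unreadable, so there is no read on how large a step this change produces. With all three measured values at a limit, compound 4 is expected to give 100000 nM in this assay, with a range from 30000 nM to 300000 nM. The step of a number no higher from compound 3 to compound 4 (the limit leaves the size open) is expected to be none beyond the scatter, with the value most likely reported again as a limit.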

Compound 4, half-maximal inhibitory concentration: > 100000 nM
Compound 4 gave a limit, no number; the forecaster's own chance of this, stated with the estimate: 85%; the middle value sits exactly at the limit.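

In this assay compound 4 gives > 100000 nM, which is a limit of the assay and not a number. Its steps to compound 1, compound 2 and compound 3 cannot be read in size or direction. The compounds shown leave open whether either the amide-type nitrogen substituent or the added methyl changes inhibition at all.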